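A Bromo for Methyl Swap in a Cytotoxicity Test

The source may report more compounds than this note shows. Statements on the series, on what has been measured and on what is new or still open speak of the compounds shown alone.

Among the compounds with values here, compound 2 (`COC(=O)c1ccc(NCc2cncn2Cc2ccccc2C)cc1-c1ccccc1`) gives 10000 nM in a toxicity assay on NIH3T3 cells (Mus musculus) for cytotoxicity, read by resazurin assay (a lower number here means that less compound is needed, a higher number that more compound is needed for the effect), and it is the only compound here with an actual number. Compound 1 (`CNC(=O)c1ccc(NCc2cncn2Cc2ccc(-c3ccccc3)cc2N)cc1-c1ccccc1`) is reported as > 1000 nM, which is a limit and not a number. Compound 3 (`N#Cc1ccc(NCc2cncn2Cc2ccc(-c3ccccc3)cc2N)cc1-c1ccccc1`) is reported as > 1000 nM, which is also a limit.

The next compound to be tested, compound 4 (`COC(=O)c1ccc(NCc2cncn2Cc2ccccc2Br)cc1-c1ccccc1`), differs from compound 2 in a single place: bromo in place of methyl on an aromatic carbon. This is bromo in place of methyl on an aromatic carbon, so the 2-methylbenzyl group becomes a 2-bromobenzyl group.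

Within the data shown here, no measured step in this small set makes that swap. Among the measured compounds shown here, the only step available is a step that the two limits leave unreadable from compound 1 to compound 3, and it involves cyano in place of methylcarbamoyl, a different change, so it offers no size to borrow. The forecast therefore starts from compound 2 at 10000 nM and assumes no shift beyond the scatter in this assay, in either direction. The expected size of the change is no change at the digits printed from compound 2 to compound 4 (within the scatter). The estimated value for compound 4 is 10000 nM, with an expected range from 3500 nM to 30000 nM.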

Compound 4, half-maximal effective concentration: 10000 nM
For compound 4 middle estimate and measured number coincide at the digits printed, within the range that was stated.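

In this assay, bromo in place of methyl on an aromatic carbon gives no change at the digits printed from compound 2 to compound 4 (within the scatter). Within the data shown here, this is the first step in the set whose size can be read, since the only earlier step, between compound 1 and compound 3, joins two results that are limits and not numbers: the limit of > 1000 nM in this assay, at which 2 of the 4 values shown sit. It shows that, with the rest of compound 2 held fixed, the 2-methylbenzyl and 2-bromobenzyl versions cannot be told apart in this test, although this holds for this one pair only and gives no reason for the match.

The compounds shown leave open whether any other group at this place would also leave the reading in the same range, for instance an amine, a carboxylic acid, a methoxy group or a longer chain such as propyl. They also leave open whether the same swap of methyl for bromo would give the same result on a different core, such as the core of compound 1, where no comparison of this kind is available.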